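The source may hold more compounds than are shown below. What is called first, only, known or untested is meant among the compounds shown, and "the series" means these compounds.

In an in vitro functional assay on 1321-N1 cells for agonist activity at P2Y purinoceptor 2 (Homo sapiens), read by scintillation proximity assay and inositol phosphate accumulation (on this read-out lower numbers stand for an effect already at smaller amounts and higher numbers for an effect only at larger amounts of compound), compound 1 `Nc1nc(=O)ccn1[C@@H]1O[C@H](COP(=O)(O)OP(=O)(O)O)[C@@H](O)[C@H]1O` gives 604 nM, compound 2 `CSc1nc(=O)ccn1[C@@H]1O[C@H](COP(=O)(O)OP(=O)(O)O)[C@@H](O)[C@H]1O` gives 523 nM, and compound 3 `COc1nc(=O)ccn1[C@@H]1O[C@H](COP(=O)(O)OP(=O)(O)O)[C@@H](O)[C@H]1O` gives 907 nM. Compound 3 stands at the upper edge of these three numbers, yet a 1.5-fold higher number from compound 1 to compound 3 (0.18 log units; within the scatter) and a 1.7-fold higher number from compound 2 to compound 3 (0.24 log units; within the scatter) both fall within the scatter, so the three cannot be told apart. Compound 4 `O=c1ccn([C@@H]2O[C@H](COP(=O)(O)OP(=O)(O)O)[C@@H](O)[C@H]2O)c(SCc2ccccc2)n1` differs from compound 3 by benzylsulfanyl in place of methoxy on an aromatic carbon. Within the data shown here, the only measured exchange touching a sulfur group at this carbon is a 1.7-fold higher number from compound 2 to compound 3 (0.24 log units; within the scatter), small and within the scatter; the benzyl part has no measured precedent. Compound 4 is therefore expected to stay near compound 3, with a 1.8-fold lower number from compound 3 to compound 4 (0.26 log units; within the scatter) anticipated. Compound 4 is estimated at 500 nM in this assay, with a range from 150 nM to 2000 nM.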

Compound 4, half-maximal effective concentration: 6200 nM
Compound 4: middle estimate off by 12-fold (1.09 log units), on the low side, and the stated range ends below it.
By their numbers in this assay, from the lowest: compounds 2, 1 and 3 (each within the scatter of the next); then compound 4.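

Amino, methylsulfanyl and methoxy could not be told apart at this carbon, but benzylsulfanyl breaks from them, with a 6.8-fold higher number from compound 3 to compound 4 (0.83 log units; beyond the scatter) and a 10-fold higher number from compound 1 to compound 4 (1.01 log units; beyond the scatter). Among these compounds, the closest comparison is a 12-fold higher number from compound 2 to compound 4 (1.07 log units; beyond the scatter), where the only change is phenyl in place of hydrogen on the saturated chain carbon bound to the sulfur, so the rise goes with the added phenyl and not with sulfur at this carbon alone. Nothing available explains the rise.

Going by these compounds, what an ethylsulfanyl group would give here stays open. So does whether a phenylethylsulfanyl chain or a methoxy group on the phenyl ring would move the number further.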